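Methyl to Hydrogen on an Aromatic Oxygen: Expected Cytotoxicity

A few compounds are considered here, and "the series" means these few. Any claim that something is new, unique, unknown or untested is made for them only; others in the source may bear on it.

Compound 1 `O=C1C=C(CCc2ccccc2)O[C@H](C[C@H]2CC=CC(=O)O2)C1`: 20400 nM
Compound 2 `O=C1C=C(/C=C/c2ccccc2)O[C@H](C[C@H]2CC=CC(=O)O2)C1`: 13200 nM
Compound 3 `COc1ccc([C@@H]2CC(=O)c3c(O)cc(C(C)=O)cc3O2)cc1`: > 83000 nM

Of the compounds shown here, three have been measured in an ADME assay on HEK293 cells (Homo sapiens) for cytotoxicity, read by resazurin assay, with a stated time of 72 h; a higher number here means a weaker inhibitor, a lower number a stronger inhibitor. Compound 1 gives 20400 nM and compound 2 gives 13200 nM. For compound 3 the assay returned only a limit, > 83000 nM, and not a number. Compound 3 thus stands at the limit of > 83000 nM in this assay, at which 1 of the 3 values shown sits.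

Compound 4 `CC(=O)c1cc(O)c2c(c1)O[C@H](c1ccc(O)cc1)CC2=O` has not yet been measured. It differs from compound 3 in one place: hydrogen in place of methyl on an oxygen on an aromatic ring. Within the data shown here, no measured pair differs in this way, so the data give no guide to the size of such a change in this assay. The step from compound 3 to compound 4 is expected to be a step that the limit leaves unreadable from compound 3 to compound 4, not beyond the scatter. Compound 4 is therefore estimated at 90000 nM, within a range from 40000 nM to 200000 nM, most likely again reported only as a limit.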

Compound 4, half-maximal inhibitory concentration: > 167000 nM
Compound 4: a limit, no number; the forecaster's own chance of this, stated with the estimate: 70%; middle value at least 1.8-fold (0.26 log units) from the limit.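

In this assay compound 3 and compound 4 each return only a limit, and no step can be read between them. The compounds shown leave open how far the change from methoxy to hydroxy shifts cytotoxicity.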